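The Same Change Tried on a Second Core

The compounds below may be only part of what the source reports. "The series", "measured", "known", "first", "only" and "open" are said of these compounds alone.

Of the compounds shown here, three sharing one core have been tested in a functional assay on MKN-74 cells (Homo sapiens) for antiproliferative activity, with a stated time of 24 h; a lower number here means a stronger inhibitor, a higher number a weaker inhibitor. Compound 1, `Cc1ccc(C(=O)Nc2sc3c(c2C(N)=O)CCN(Cc2ccc(Cl)cc2Cl)C3)cc1`, gives 25500 nM. Compound 2, `NC(=O)c1c(NC(=O)c2cccc([N+](=O)[O-])c2)sc2c1CCN(Cc1ccc(Cl)cc1Cl)C2`, differs from compound 1 only by 3-nitrophenyl in place of 4-methylphenyl on a carbonyl carbon. In this assay compound 2 gives 16500 nM, and the step is a 1.5-fold lower number from compound 1 to compound 2 (0.19 log units; within the scatter). Compound 3, `Cc1ccc(C(=O)Nc2sc3c(c2C(N)=O)CCN(C(=S)Nc2ccccc2Cl)C3)cc1`, keeps the (4-methylphenyl)carbonyl of compound 1 but carries a different group on the ring nitrogen: a group of 10 heavy atoms (7 carbon, 1 nitrogen, 1 sulfur, 1 chlorine; one six-membered aromatic ring of carbon only) in place of a group of 9 heavy atoms (7 carbon, 2 chlorine; one six-membered aromatic ring of carbon only), on an amine nitrogen in a ring. In this assay compound 3 gives 11300 nM, and the step is a 2.3-fold lower number from compound 1 to compound 3 (0.35 log units; beyond the scatter). Compound 3 and compound 2 lie within the scatter of each other, so nothing separates them; only compound 1 stands apart from compound 3.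

Compound 4, `NC(=O)c1c(NC(=O)c2cccc([N+](=O)[O-])c2)sc2c1CCN(C(=S)Nc1ccccc1Cl)C2`, has not yet been measured. It carries the core of compound 3 and differs from it by 3-nitrophenyl in place of 4-methylphenyl on a carbonyl carbon. This is the same change that turns compound 1 into compound 2, made at the same place, on a carbonyl carbon whose other neighbour is an amide-type nitrogen. For compound 4 the step of a 1.4-fold lower number from compound 3 to compound 4 (0.15 log units; within the scatter) is expected to be of similar size, because on the other core the same change gave a 1.5-fold lower number from compound 1 to compound 2 (0.19 log units; within the scatter). Among the measured compounds shown here, with only one earlier example, on a core that differs from that of compound 3 in the group on the ring nitrogen, this expectation rests on a thin base, and the step could land anywhere within the scatter. Compound 4 is therefore estimated at 8000 nM, with a likely range from 3500 nM to 18000 nM.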

Compound 4, half-maximal inhibitory concentration: 8850 nM
Estimate against measurement, compound 4: 1.1-fold (0.04 log units) below; measured number inside the range.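

In this assay, putting 3-nitrophenyl in place of 4-methylphenyl on the core that carries the group of compound 3 gives a 1.3-fold lower number from compound 3 to compound 4 (0.11 log units; within the scatter), and this agrees with the same change on the other core: the same change on two cores in this assay, a 1.5-fold lower number (0.19 log units; within the scatter) from compound 1 to compound 2 and a 1.3-fold lower number (0.11 log units; within the scatter) from compound 3 to compound 4, 1.2-fold (0.08 log units) apart, within the scatter of two such steps. The change on the ring nitrogen, now read with 3-nitrophenyl in place, gives a 1.9-fold lower number from compound 2 to compound 4 (0.27 log units; within the scatter), and it also agrees with its earlier counterpart: the same change on two cores in this assay, a 2.3-fold lower number (0.35 log units; beyond the scatter) from compound 1 to compound 3 and a 1.9-fold lower number (0.27 log units; within the scatter) from compound 2 to compound 4, 1.2-fold (0.08 log units) apart, within the scatter of two such steps. So, in these four compounds, each change gave a step of similar size on both cores, but this rests on a single pair of steps for each change, and since both 3-nitrophenyl steps lie within the scatter, they do not show that this swap changes activity on either core.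

The compounds shown leave open whether a group that gives a step clearly beyond the scatter would carry over between the two cores as closely, for example an amine or a carboxylic acid on the phenyl ring in place of the nitro group. They also leave open whether the agreement would hold for ring nitrogen groups other than the two seen here, such as a simple methyl or a longer alkyl chain.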